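Expected cytotoxicity after one more amide-side swap

This account rests on a few compounds, and the source may have more. Where it says the series, first, only, none or still open, it means among the compounds named here.

Measured in an ADME assay on MT4 cells (Homo sapiens) for cytotoxicity, read by MTT assay; on this read-out lower numbers stand for higher toxicity in this test and higher numbers for lower toxicity in this test:
- compound 1 `Cc1cc(C)cc(S(=O)(=O)c2c(C(=O)Nc3ccccc3O)[nH]c3ccc(Cl)cc23)c1`: 19700 nM
- compound 2 `Cc1cc(C)cc(S(=O)(=O)c2c(C(=O)Nc3cccc(O)c3)[nH]c3ccc(Cl)cc23)c1`: 24600 nM
- compound 3 `Cc1cc(C)cc(S(=O)(=O)c2c(C(=O)NCc3ccc(CO)cc3)[nH]c3ccc(Cl)cc23)c1`: 31100 nM

Compound 3 stands within the scatter of both other compounds, with a 1.6-fold higher number from compound 1 to compound 3 (0.20 log units; within the scatter) and a 1.3-fold higher number from compound 2 to compound 3 (0.10 log units; within the scatter). Compound 4 `COc1cc(CNC(=O)c2[nH]c3ccc(Cl)cc3c2S(=O)(=O)c2cc(C)cc(C)c2)ccc1O` keeps the shared core and changes one group: 4-hydroxy-3-methoxyphenyl in place of 4-(hydroxymethyl)phenyl on a saturated chain carbon bound to an amide-type nitrogen. This swap sits on a saturated chain carbon bound to an amide-type nitrogen. Changes to the group on that nitrogen have stayed small so far, as a 1.2-fold higher number from compound 1 to compound 2 (0.10 log units; within the scatter) also shows. On these data alone, the incoming group itself is untested, but no step beyond the scatter is expected in this assay. The expected change is a 1.2-fold lower number from compound 3 to compound 4 (0.09 log units; within the scatter). For compound 4 the estimated value is 25000 nM, with an expected range of 11000 nM to 50000 nM.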

Compound 4, half-maximal cytotoxic concentration: 28700 nM
For compound 4 the middle estimate is 1.1-fold (0.06 log units) below the measured one; measured number inside the range.
By their numbers in this assay, from the lowest: compounds 1, 2, 4 and 3 (each within the scatter of the next).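

In this assay, the swap to 4-hydroxy-3-methoxyphenyl, which brings one more oxygen on the ring, gives a 1.1-fold lower number from compound 3 to compound 4 (0.03 log units; within the scatter) and so leaves the number in place within the scatter. Compound 4 also sits close to the compounds with a ring directly on the amide-type nitrogen, with a 1.2-fold higher number from compound 2 to compound 4 (0.07 log units; within the scatter) and a 1.5-fold higher number from compound 1 to compound 4 (0.16 log units; within the scatter) so this position has now tolerated a second substitution pattern on the benzyl ring without a step beyond the scatter. Nothing available here explains this flatness.

All four compounds carry an oxygen-bearing aromatic ring on that nitrogen. On these data alone, whether an amine, a carboxylic acid or a longer chain there would stay equally close remains open.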